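From 4-methoxyphenyl to 3-methoxyphenyl: compound 2 to compound 3

The source may hold more compounds than are shown below. What is called first, only, known or untested is meant among the compounds shown, and "the series" means these compounds.

Values measured in a functional assay on BaF3 cells (Mus musculus) for inhibition, read by MTT assay, with a stated time of 3 days (a higher number here means a weaker inhibitor of growth, a lower number a stronger inhibitor of growth), are as follows.
- Compound 1 `O=C(Nc1ccc(Cl)cc1)Nc1ccc(Nc2ncnc3c2OCCN3)cc1` gives > 10000 nM as a limit.
- Compound 2 `COc1ccc(NC(=O)Nc2ccc(Nc3ncnc4c3OCCN4)cc2)cc1` gives > 10000 nM as a limit.

Within the data shown here, compound 2 has no numerical value, only a limit, and the one other value shown is also a limit. Among the measured compounds shown here, the whole series so far consists of the limit of > 10000 nM in this assay, at which 2 of the 2 values shown sit, and gives no order among its members.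

The next structure is compound 3 `COc1cccc(NC(=O)Nc2ccc(Nc3ncnc4c3OCCN4)cc2)c1` and its change from compound 2 is 3-methoxyphenyl in place of 4-methoxyphenyl on an amide-type nitrogen with the same atoms joined differently. In words, 3-methoxyphenyl stands in place of 4-methoxyphenyl on an amide-type nitrogen.

For the measured compounds named here, the only measured step is a step that the two limits leave unreadable from compound 1 to compound 2 and it bears on this change only as a swap of one group at the far end of the molecule. Since a step that the two limits leave unreadable from compound 1 to compound 2 has no readable size, there is no size to carry over and no direction to favour. The expected result is a number no higher from compound 2 to compound 3 (the limit leaves the size open) in this assay with nothing beyond the scatter anticipated, and a further limit is the likeliest report. For compound 3 the estimate is 10000 nM with an expected range from 3000 nM to 20000 nM in this read-out.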

Compound 3, concentration for 50% growth inhibition: > 10000 nM
Compound 3: a limit, no number; the forecaster's own chance of this, stated with the estimate: 70%; the middle value lies on the limit itself.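

In this assay compound 3 gives > 10000 nM, a limit and not a number. Among these compounds, no step among compound 1, compound 2 and compound 3 can be read: the limit of > 10000 nM in this assay, at which 3 of the 3 values shown sit. The compounds shown leave open how these three rank and whether 3-methoxyphenyl and 4-methoxyphenyl differ at all in growth inhibition.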